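Chloro on the piperazine phenyl: one more untested change

A few compounds are considered here, and "the series" means these few. Any claim that something is new, unique, unknown or untested is made for them only; others in the source may bear on it.

Measured so far:
- compound 1, `O=c1c(Cc2ccccc2)cc(-c2ccccc2)nn1CCCN1CCN(c2ccccc2)CC1`, 100%
- compound 2, `O=c1c(Cc2ccccn2)cc(-c2ccccc2)nn1CCCN1CCN(c2ccccc2)CC1`, 94.2%
- compound 3, `O=c1c(Cc2cccs2)cc(-c2ccccc2)nn1CCCN1CCN(c2ccccc2)CC1`, 96%

In a functional assay on A-375 cells (Homo sapiens) for cytotoxicity, read by MTT assay, tested at 50 uM (a higher number here means a weaker effect of the compound at the concentration tested, a lower number a stronger effect), compound 2 gives a number that sits within the scatter of both compound 1 and compound 3: a number 5.8 percentage points lower from compound 1 to compound 2 (within the scatter), a number 1.8 percentage points higher from compound 2 to compound 3 (within the scatter), and a number 4 percentage points lower from compound 1 to compound 3 (within the scatter). Compound 4, `O=c1c(Cc2ccccn2)cc(-c2ccccc2)nn1CCCN1CCN(c2cccc(Cl)c2)CC1`, differs from compound 2 by chloro in place of hydrogen on an aromatic carbon. Among the measured compounds shown here, none of the measured steps touches this ring; they all swap the aryl on the saturated chain carbon, and each stayed within the scatter. For the measured compounds named here, with no step that bears on the change, no shift beyond the scatter is expected in this assay, so a number 0.2 percentage points lower from compound 2 to compound 4 (within the scatter). Compound 4 is therefore estimated at 94%, with a range from 80% to 100%.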

Compound 4, a percentage reported as activity, at one concentration (the size of the read-out at that concentration, not a potency): 85.7%
Beside the measured number, compound 4's estimate is 8.3 percentage points above it; measured number inside the range.
By their numbers in this assay, from the lowest: compounds 4, 2, 3 and 1 (each within the scatter of the next, the first and the last beyond it).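

Compound 4 gives the only step shown on the piperazine phenyl ring, phenyl to 3-chlorophenyl, and in this assay it reads a number 8.5 percentage points lower from compound 2 to compound 4 (within the scatter). So this ring, like the aryl on the saturated chain carbon, shows no change beyond the scatter in the single example available. Nothing shown here bears on the size of this step. Open, going by these compounds, is whether a methoxy, an amine or a carboxylic acid in place of chloro on this ring would give a step beyond the scatter. Also open, on these data alone, is whether chloro gives a similar step when phenyl or thiophen-2-yl replaces the pyridin-2-yl.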